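A few compounds are considered here, and "the series" means these few. Any claim that something is new, unique, unknown or untested is made for them only; others in the source may bear on it.

Compound 1 `CC1=Cc2c(cc(C)oc2=O)OC1C` — "not determined" (no result reported)
Compound 2 `Cc1cc2c(c(=O)o1)C=C(C(C)C)C(CC(C)C)O2` — 94%

Two compounds were made, but only one of them carries a number. In a functional assay on SH-SY5Y cells (Homo sapiens) for antiproliferative activity, with a stated time of 24 h, tested at 12.5 ug/mL (a higher number here means a stronger effect of the compound at the concentration tested, a lower number a weaker effect), compound 2 gives 94%, a strong effect at the concentration tested. For compound 1 the entry in this assay reads "not determined" (no result reported), so compound 2 stands alone as the only measured point and cannot be ranked against anything.

Compound 3 `Cc1cc2c(c(=O)o1)C=C(c1ccccc1)C(CC(C)C)O2` has not yet been tested. It differs from compound 2 in one place: phenyl in place of isopropyl on a double-bonded ring carbon. Among the measured compounds shown here, no step between two measured compounds is known here, so there is nothing to calibrate the size of this change against. The reading of compound 2 already lies close to the top of what this assay can report, which leaves little room for an increase; a change of this kind could leave the effect about where it is or pull it down somewhat. The step of a number 9 percentage points lower from compound 2 to compound 3 (within the scatter) is expected to be small, downward if anything, and may lie within the usual scatter. Compound 3 is expected to give about 85%, with a range from 60% to 100%.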

Compound 3, a percentage reported as inhibition, at one concentration (the size of the read-out at that concentration, not a potency): 14.6%
Compound 3: the middle estimate sits 70.4 percentage points above what was measured; measured number outside the range, below it.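

Putting phenyl in place of isopropyl on the double-bonded ring carbon gives a number 79.4 percentage points lower from compound 2 to compound 3 (beyond the scatter) in this assay, so the effect at the concentration tested depends strongly on which group sits at this one place on the core. Neither group carries a hydrogen-bond donor, a hydrogen-bond acceptor or a net charge, so a swap between two groups made only of carbon is enough to produce a step of this size. Nothing shown here gives a reason for the drop.

This is a single step between two compounds, read at one concentration, so it shows a change in effect at that concentration rather than a change in potency, and it sets no rule for other groups at this place or for other cores. As far as these compounds go, whether a cyclohexyl group here would keep the effect close to that of compound 2 or lose it as compound 3 does remains open, as does whether a phenyl bearing an amine would recover any of the effect.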